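The compounds below may be only part of what the source reports. "The series", "measured", "known", "first", "only" and "open" are said of these compounds alone.

Measured so far in an assay on isolated protein for binding affinity to melanin-concentrating hormone receptor 1 (Homo sapiens), read by radioligand binding; a lower number here means a stronger inhibitor, a higher number a weaker inhibitor:

compound 1 `CCN(CC)Cc1cnc2c(CNC(=O)c3ccc(-c4ccc(F)cc4)nc3)cccc2c1`: 310 nM
compound 2 `O=C(NCc1cccc2cc(CN3CCC(O)CC3)cnc12)c1ccc(-c2ccc(F)cc2)nc1`: 803 nM

For the measured compounds named here, compound 2 stands at the higher of the two numbers; its nearest neighbour is compound 1, and the only step on record, a 2.6-fold higher number from compound 1 to compound 2 (0.41 log units; beyond the scatter), separates them. Going by the values given here, that step is the single piece of evidence bearing on the next change, since it also swaps the amine on the saturated chain carbon bound to an aromatic carbon.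

Compound 3 `CN1CCN(Cc2cnc3c(CNC(=O)c4ccc(-c5ccc(F)cc5)nc4)cccc3c2)CC1` is not yet measured. Its difference from compound 2 is 4-methylpiperazin-1-yl in place of 4-hydroxypiperidin-1-yl on a saturated chain carbon bound to an aromatic carbon. Among the compounds with values here, the one recorded step shows that this position tolerates a change of amine with only a modest shift, so a modest step is expected here, most likely back toward the lower number of compound 1, though a step within the scatter cannot be excluded. The expected step is a 1.8-fold lower number from compound 2 to compound 3 (0.25 log units; within the scatter). For compound 3 the estimate in this assay is 450 nM, with a range from 150 nM to 1300 nM.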

Compound 3, inhibition constant: 3540 nM
Estimate against measurement, compound 3: 7.9-fold (0.90 log units) below, and the stated range ends below it.
By their numbers in this assay, from the lowest: compound 1; then compound 2; then compound 3.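

In this assay, for the compounds shown here, the step of a 4.4-fold higher number from compound 2 to compound 3 (0.64 log units; beyond the scatter) shows that this position is more sensitive to the amine than the first step suggested, and the step of an 11-fold higher number from compound 1 to compound 3 (1.06 log units; beyond the scatter) is the only large one so far. The 4-hydroxypiperidin-1-yl and 4-methylpiperazin-1-yl groups have the same heavy-atom count and both are six-membered non-aromatic rings, so a change that leaves both counts intact still moves the number beyond the scatter. No measurement shown gives a reason for either step.

The compounds shown leave open whether the higher number of compound 3 goes with the second ring nitrogen or with its methyl, which piperazin-1-yl without the methyl would separate. They also leave open how morpholin-4-yl or a smaller open-chain amine such as dimethylamino would read at this position.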